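This account rests on a few compounds, and the source may have more. Where it says the series, first, only, none or still open, it means among the compounds named here.

Compound 1 `CC1=CCCC(C)(C)C1/C=C/C(=O)/C=C/c1cccc(C(F)(F)F)c1`: 4400 nM
Compound 2 `CC1=CCCC(C)(C)C1/C=C/C(=O)/C=C/c1cc(C(F)(F)F)ccc1F`: 3000 nM

Among the compounds with values here, in a functional assay on PCa 2b cells (Homo sapiens) for cytotoxicity, read by MTT assay, with a stated time of 72 h (a lower number here means a stronger inhibitor, a higher number a weaker inhibitor), compound 1 gives the higher of these two numbers, with compound 2 close by: the only measured step, fluoro in place of hydrogen on an aromatic carbon, a 1.5-fold lower number from compound 1 to compound 2 (0.17 log units; within the scatter), stays within the scatter. Compound 3 `CC1=CCCC(C)(C)C1/C=C/C(=O)/C=C/c1cccc([N+](=O)[O-])c1` differs from compound 1 by nitro in place of trifluoromethyl on an aromatic carbon. Within the data shown here, no measured step swaps one whole group for another in this way, so that single small step bears on it only loosely. The expected step from compound 1 to compound 3 in this assay is therefore small, a 1.1-fold lower number from compound 1 to compound 3 (0.04 log units; within the scatter), with no clear direction. Compound 3 is estimated at 4000 nM, between 1500 nM and 11000 nM.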

Compound 3, half-maximal inhibitory concentration: 5900 nM
Beside the measured number, compound 3's estimate is 1.5-fold (0.17 log units) below it; measured number inside the range.
By their numbers in this assay, from the lowest: compounds 2, 1 and 3 (each within the scatter of the next).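

In this assay, the exchange of one whole group for another at this position, on an aromatic carbon meta to a large group, gives a 1.3-fold higher number from compound 1 to compound 3 (0.13 log units; within the scatter) and so stays within the usual scatter. The reading at this position thus stays put even when trifluoromethyl gives way to nitro, a group with different atoms and with hydrogen-bond acceptors. Nothing measured here gives a reason for this result. As far as these compounds go, whether an amine or a carboxylic acid at this position would also leave the number in this range stays open, and so does the effect of a longer chain there.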